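This account rests on a few compounds, and the source may have more. Where it says the series, first, only, none or still open, it means among the compounds named here.

Measured so far:
compound 1 `O=C(CSc1nncnc1-c1cccc2ccccc12)N1CCc2ccccc2C1` — 13000 nM
compound 2 `CCOC(=O)c1ccc(NC(=O)CSc2nncnc2-c2ccccc2Cl)c(Br)c1` — 69000 nM
compound 3 `CCOC(=O)c1ccc(NC(=O)CSc2nncnc2-c2cccc3ccccc23)c(Cl)c1` — 150000 nM

In an ADME assay on MT4 cells (Homo sapiens) for cytotoxicity, read by MTT assay (on this read-out higher numbers stand for lower toxicity in this test and lower numbers for higher toxicity in this test), compound 2 stands second highest of the three numbers; compound 3 reads higher and compound 1 reads lower, both gaps beyond the scatter. Compound 4 `O=C(CSc1nncnc1-c1ccccc1Cl)Nc1ccccc1Br` is not yet measured in this assay. It differs from compound 2 in one place: hydrogen in place of ethoxycarbonyl on an aromatic carbon. Within the data shown here, no step of this kind has been measured, so the direction of the change is open. With only the value of compound 2 as an anchor, the expected step of a 1.3-fold lower number from compound 2 to compound 4 (0.10 log units; within the scatter) is taken as none beyond the scatter. Compound 4 is therefore estimated at 55000 nM in this assay, with a range from 15000 nM to 200000 nM.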

Compound 4, half-maximal cytotoxic concentration: 73000 nM
Compound 4: middle estimate off by 1.3-fold (0.12 log units), on the low side; low and high end bracket the measured number.
By their numbers in this assay, from the lowest: compound 1; then compounds 2 and 4 (each within the scatter of the next); then compound 3.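

In this assay, hydrogen in place of ethoxycarbonyl on this aromatic carbon, meta to a bromo group, gives a 1.1-fold higher number from compound 2 to compound 4 (0.02 log units; within the scatter). This is the only one-place step among the compounds shown, and it shows that losing these 5 heavy atoms at this position leaves the read-out within the scatter. No supporting measurement bears on this result. From the compounds shown here alone, whether an amine or a carboxylic acid at this position would read the same remains open. Going by these compounds, whether the same step holds alongside the other aromatic group of compound 3 also remains open.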